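Swapping fluoro for chloro on an aromatic carbon

A few compounds are considered here, and "the series" means these few. Any claim that something is new, unique, unknown or untested is made for them only; others in the source may bear on it.

- Compound 1 `COCc1ccccc1C1CCc2nc[nH]c2C1` gives 2.2; 2.2 (2 entries)
- Compound 2 `Fc1ccccc1C1Cc2nccn2C1` gives 2

Both values come from a physicochemical assay for lipophilicity, at pH 7.4; on this read-out lower numbers stand for lower lipophilicity and higher numbers for higher lipophilicity. Within the data shown here, compound 2 stands at 2, the only number available for it, since one further entry gives no single number. Its value and that of compound 1 lie within the usual scatter of each other, so the two cannot be ranked.

Compound 3 `Clc1ccccc1C1Cc2nccn2C1` has not yet been measured. It differs from compound 2 in one place: chloro in place of fluoro on an aromatic carbon. Among the measured compounds shown here, no measured pair here shows a swap of this kind, so the expectation rests on the structural change alone. The expected change is a small rise in this assay, slightly beyond the scatter, estimated as a number 0.40 log units higher from compound 2 to compound 3 (beyond the scatter). For compound 3 the estimated value is 2.4, with an expected range from 2 to 2.8.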

Compound 3, distribution coefficient: 2.6
The estimate for compound 3 lay 0.20 log units below the measured number, within the range that was stated.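

In this assay, among these compounds, chloro in place of fluoro on an aromatic carbon gives a number 0.60 log units higher from compound 2 to compound 3 (beyond the scatter) and this is the first measured swap of this kind at this position. The change is small on paper, with one heavy atom leaving and one entering, no ring involved and no hydrogen-bond donor, hydrogen-bond acceptor or net charge on either group, yet the step lies beyond the usual scatter. Nothing available accounts for the size of this step.

Going by these compounds, whether the same swap would give a similar step on the core of compound 1, or at another carbon of this six-membered aromatic ring, remains open. Also open, on these data alone, is how the read-out would respond to other groups at this position, such as a methoxy group, an amine or a carboxylic acid.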